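Ethoxycarbonyl in place of hydroxymethyl on compound 3

The source may hold more compounds than are shown below. What is called first, only, known or untested is meant among the compounds shown, and "the series" means these compounds.

In a physicochemical assay for solubility, read by HPLC, at pH 7.4 (on this read-out lower numbers stand for lower solubility and higher numbers for higher solubility), compound 1 (`CCOCCCCc1cc(=O)c2cc(C(F)(F)F)ccc2[nH]1`) is reported as > 200000 nM, which is a limit and not a number. Among the actual numbers, compound 2 (`CCCCCCCc1[nH]c2ccccc2c(=O)c1CO`) gives 50000 nM and compound 3 (`CCCCCCCc1[nH]c2ccc([N+](=O)[O-])cc2c(=O)c1CO`) gives 5000 nM, the lower of the two. Within the data shown here, the only measured step, a 10-fold lower number from compound 2 to compound 3 (1.00 log units; beyond the scatter), is nitro in place of hydrogen on an aromatic carbon, and it lies beyond the scatter.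

Compound 4 (`CCCCCCCc1[nH]c2ccc([N+](=O)[O-])cc2c(=O)c1C(=O)OCC`) has ethoxycarbonyl in place of hydroxymethyl on an aromatic carbon, ortho to a heptyl group: ethoxycarbonyl in place of hydroxymethyl on an aromatic carbon. Among the measured compounds shown here, no measured step involves this exchange, so the evidence is thin. With a 10-fold lower number from compound 2 to compound 3 (1.00 log units; beyond the scatter) as the only available scale, a smaller move toward a lower number is expected, and a result within the scatter of compound 3 remains possible. The expected change is a 3.3-fold lower number from compound 3 to compound 4 (0.52 log units; beyond the scatter). Compound 4 is estimated at 1500 nM, with an expected range of 300 nM to 6000 nM.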

Compound 4, solubility: 5000 nM
Beside the measured number, compound 4's estimate is 3.3-fold (0.52 log units) below it; low and high end bracket the measured number.
By their numbers in this assay, from the lowest: compounds 3 and 4 (each within the scatter of the next); then compound 2. At a limit, above all of these: compound 1.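

In this assay, the aromatic carbon ortho to a heptyl group and two atoms from the ring nitrogen accepts ethoxycarbonyl in place of hydroxymethyl with no change at the digits printed from compound 3 to compound 4 (within the scatter) as the outcome. Among these compounds, the group that enters has 5 heavy atoms and 0 hydrogen-bond donors, against 2 heavy atoms and 1 hydrogen-bond donor in the group that leaves, yet on this nitro-bearing pair that exchange stays within the scatter, whereas the only earlier step concerned nitro on the ring and lay beyond it. Nothing measured here bears on why the read-out holds at this position.

Going by these compounds, whether the same exchange would behave alike on compound 2, which carries hydrogen in place of nitro, remains open. So does what a carboxylic acid or an amine at this position, or a longer chain in place of heptyl, would do to the read-out.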